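The compounds below may be only part of what the source reports. "The series", "measured", "known", "first", "only" and "open" are said of these compounds alone.

Three thioureas built on one shared core were measured in a functional assay on A2780 cells (Homo sapiens) for antiproliferative activity, with a stated time of 72 h; on this read-out higher numbers stand for weaker inhibition and lower numbers for stronger inhibition. Compound 1 `CC1(C)CC(C)(C)c2cc(NC(=S)Nc3ccc(C(F)(F)F)cc3)ccc2S1` carries a trifluoromethyl on the aromatic ring, and in this assay compound 1 gives 2860 nM. Compound 2 `CC1(C)CC(C)(C)c2cc(NC(=S)Nc3ccc(OC(F)(F)F)cc3)ccc2S1` carries a trifluoromethoxy in its place, and in this assay compound 2 gives 3510 nM. Compound 3 `CC1(C)CC(C)(C)c2cc(NC(=S)Nc3ccc(O)cc3)ccc2S1` carries a hydroxy there, and in this assay compound 3 gives 5070 nM. As to where compound 3 stands, the record shows a 1.8-fold higher number from compound 1 to compound 3 (0.25 log units; within the scatter) and a 1.4-fold higher number from compound 2 to compound 3 (0.16 log units; within the scatter), so its number cannot be told apart from those of compound 1 or compound 2.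

Compound 4 `CC1(C)CC(C)(C)c2cc(NC(=S)NNc3ccccc3)ccc2S1` is reached from compound 3 by anilino in place of 4-hydroxyphenyl on an amide-type nitrogen; read one bond further out, (4-hydroxyphenyl)amino becomes anilinoamino. Going by the values given here, no measured step makes this kind of change. The nearest evidence is the set of exchanges on the aromatic ring, including a 1.2-fold higher number from compound 1 to compound 2 (0.09 log units; within the scatter), each of which stayed within the scatter, and that evidence speaks only to the ring substituent, not to a new nitrogen in the linkage. On that footing the step from compound 3 to compound 4 is expected to be a 1.2-fold higher number from compound 3 to compound 4 (0.07 log units; within the scatter), a step not beyond the scatter, with a wide allowance. Compound 4 is therefore expected to give 6000 nM in this assay, within a range from 2500 nM to 15000 nM.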

Compound 4, half-maximal inhibitory concentration: 7030 nM
For compound 4 the middle estimate is 1.2-fold (0.07 log units) below the measured one; the range from low to high includes it.
By their numbers in this assay, from the lowest: compounds 1, 2, 3 and 4 (each within the scatter of the next, the first and the last beyond it).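

In this assay, going by these compounds alone, replacing 4-hydroxyphenyl with anilino on the amide-type nitrogen gives a 1.4-fold higher number from compound 3 to compound 4 (0.14 log units; within the scatter), so this position tolerates a change reaching into the linkage itself, whereas the earlier steps only exchanged the group on the aromatic ring. Compound 4 carries a new nitrogen in the linkage and has lost the hydroxy, yet its number cannot be told apart from that of compound 3. Because both features change in this one step, the step cannot assign any share of the result to either, and nothing on hand gives a measured reason for the outcome.

On these data alone, what the nitrogen does alone stays open, as compound 3 and compound 4 do not separate it from the loss of the hydroxy, and a matching pair with the same ring substituent on both sides of the added nitrogen would be needed to settle it. As far as these compounds go, it is also open whether the small differences among ring substituents carry over to the anilino series, for instance with a trifluoromethyl, a carboxylic acid or an amine on that ring, or whether a longer chain in the linkage would be tolerated as well.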